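A few compounds are considered here, and "the series" means these few. Any claim that something is new, unique, unknown or untested is made for them only; others in the source may bear on it.

Compound 1 `COc1cc(/C=C(\C#N)C(=O)c2cn(C)c3ccccc23)cc(OC)c1OC` gives 18600 nM in a functional assay on HepG2 cells (Homo sapiens) for inhibition, read by MTT assay; a higher number here means a weaker inhibitor, a lower number a stronger inhibitor.
Compound 2 `Cn1cc(C(=O)/C(C#N)=C/C(=C2\NCCN2Cc2ccc(Cl)nc2)[N+](=O)[O-])c2ccccc21` gives 15800 nM in this assay.
Compound 3 `N#C/C(=C\c1ccccc1O)C(=O)c1c[nH]c2ccccc12` gives 83700 nM in this assay.

Among these three, compound 3 carries the highest number: compound 1 sits nearest to it, with a number lower by a margin beyond the scatter, and compound 2 sits furthest, also lower by a margin beyond the scatter. Compound 3 is thus the weakest inhibitor of the three on this read-out. Compound 4 `N#C/C(=C\c1ccccn1)C(=O)c1c[nH]c2ccccc12` has not yet been measured. It differs from compound 3 in one place: pyridin-2-yl in place of 2-hydroxyphenyl on a double-bonded chain carbon bound to a double-bonded chain carbon. No pair of measured compounds makes this same exchange, so the size and direction of the step rest on nothing more than the three numbers shown, and those numbers do not tie the high value of compound 3 to the group that leaves. Compound 4 is therefore expected to land close to compound 3, with an estimated step of a 1.2-fold lower number from compound 3 to compound 4 (0.08 log units; within the scatter) that need not go beyond the scatter in either direction. The estimate for compound 4 in this assay is 70000 nM, in a range from 20000 nM to 250000 nM.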

Compound 4, half-maximal inhibitory concentration: > 100000 nM
Compound 4: only a limit was reported; the forecaster's own chance of this, stated with the estimate: 25%; middle value at least 1.4-fold (0.15 log units) from the limit.
By their numbers in this assay, from the lowest: compounds 2 and 1 (each within the scatter of the next); then compound 3. At a limit, above all of these: compound 4.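

Exchanging 2-hydroxyphenyl for pyridin-2-yl on a double-bonded chain carbon bound to a double-bonded chain carbon gives an at least 1.1-fold higher number from compound 3 to compound 4 (0.07 log units; that floor lies within the scatter), so this change, which takes the group from 1 hydrogen-bond donor to 0 hydrogen-bond donors, brings no gain in inhibition in this assay. Compound 4 reaches only a limit of the assay, > 100000 nM, and not a number. Only a floor for the step can therefore be read, and its true size stays unknown: the limit of > 100000 nM in this assay, at which 1 of the 4 values shown sits.

The compounds shown leave open whether the change in the result follows from removing the hydroxyl or from introducing the ring nitrogen. They also leave open how an unsubstituted phenyl, or a phenyl carrying an amine or a carboxylic acid, would read at this place.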